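This account rests on a few compounds, and the source may have more. Where it says the series, first, only, none or still open, it means among the compounds named here.

Measured so far
- compound 1, `CN(C(=O)NC(=O)c1ccc([N+](=O)[O-])cc1)c1nc(C(F)(F)F)c(C(=O)N/N=C/c2ccc([N+](=O)[O-])cc2)s1`: 9.24 ug/mL
- compound 2, `CN(C(=O)NC(=O)c1ccc(F)c(F)c1)c1nc(C(F)(F)F)c(C(=O)N/N=C/c2cc(C(F)(F)F)cc(C(F)(F)F)c2)s1`: 2.61 ug/mL

Both values come from a functional assay on MCF7 cells (Homo sapiens) for inhibition, read by MTT assay, with a stated time of 72 h; a higher number here means a weaker inhibitor, a lower number a stronger inhibitor. Compound 1 gives 9.24 ug/mL there, and compound 2 gives 2.61 ug/mL, the lower of the two numbers; the gap between them lies beyond the usual scatter. Among the compounds with values here, compound 1 and compound 2 differ in more than one place, so the two numbers show only that compound 2 sits lower, and no single change can be read from them.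

Compound 3, `CN(C(=O)NC(=O)c1cccc(C(F)(F)F)c1)c1nc(C(F)(F)F)c(C(=O)N/N=C/c2cc(C(F)(F)F)cc(C(F)(F)F)c2)s1`, has not been measured. It differs from compound 2 in one place: 3-(trifluoromethyl)phenyl in place of 3,4-difluorophenyl on a carbonyl carbon. Within the data shown here, no pair of measured compounds differs by this change alone, so nothing on hand tells how large a step to expect or in which direction. The working assumption is a step in this assay that does not go beyond the scatter; that is, compound 3 is expected to land close to compound 2, with a 1.0-fold lower number from compound 2 to compound 3 (0.00 log units; within the scatter) as the estimated step. Compound 3 is therefore estimated at 2.6 ug/mL in this assay, within a range of 1 ug/mL to 6.5 ug/mL.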

Compound 3, half-maximal inhibitory concentration: 6.08 ug/mL
Compound 3: the middle estimate sits 2.3-fold (0.37 log units) below what was measured; low and high end bracket the measured number.
By their numbers in this assay, from the lowest: compound 2; then compounds 3 and 1 (each within the scatter of the next).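

In this assay, within the data shown here, 3-(trifluoromethyl)phenyl in place of 3,4-difluorophenyl on a carbonyl carbon whose other neighbour is an amide-type nitrogen gives a 2.3-fold higher number from compound 2 to compound 3 (0.37 log units; beyond the scatter), the first change that can be read on its own. This position therefore responds to the choice of aryl group, even though both groups carry one six-membered aromatic ring of carbon only, no hydrogen-bond donors or acceptors and no net charge, and the 3,4-difluorophenyl group is the better of the two by this read-out. Nothing at hand explains the size or direction of this step.

One step cannot separate the gain of the trifluoromethyl group from the loss of the two fluorines, nor show whether the same change would give a similar step on a different remainder of the molecule. Also open, as far as these compounds go, is how this carbonyl carbon would tolerate a plain phenyl ring, a phenyl ring bearing an amine or a carboxylic acid, or an open alkyl chain in place of the ring.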